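A few compounds are considered here, and "the series" means these few. Any claim that something is new, unique, unknown or untested is made for them only; others in the source may bear on it.

Compound 3 `CC(C)(C)Cc1cnc(CCc2ccc(-c3ccccc3C(=O)O)cc2)[nH]1` gives 106 nM in an in vitro functional assay on cells for agonist activity at Bombesin receptor subtype-3 (Homo sapiens), read by luminescence and calcium flux (a higher number here means that more compound is needed for the effect, a lower number that less compound is needed), the lowest number among the three measured compounds; compound 1 `O=C(O)c1ccccc1-c1ccc(CCc2ncc(C3CCCCC3)[nH]2)cc1` gives 375 nM and compound 2 `O=C(O)c1ccccc1-c1ccc(CCc2ncc(CCc3ccccc3)[nH]2)cc1` gives 1320 nM. Compound 4 `CC(C)(C)c1cnc(CCc2ccc(-c3ccccc3C(=O)O)cc2)[nH]1` differs from compound 3 in one place: tert-butyl in place of neopentyl on an aromatic carbon. The same position has been varied before: a 3.5-fold lower number from compound 1 to compound 3 (0.55 log units; beyond the scatter), and a 12-fold lower number from compound 2 to compound 3 (1.10 log units; beyond the scatter), so this assay responds to the group there beyond the scatter. Among the compounds with values here, no measured step trims the neopentyl group itself, so the direction is uncertain. Because compound 3 gives 106 nM, the lowest number shown, a modest rise is expected for compound 4, a 2.4-fold higher number from compound 3 to compound 4 (0.37 log units; beyond the scatter). The estimate for compound 4 is 250 nM, with a range from 80 nM to 800 nM.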

Compound 4, half-maximal effective concentration: 4330 nM
Beside the measured number, compound 4's estimate is 17-fold (1.24 log units) below it; measured number outside the range, above it.
By their numbers in this assay, from the lowest: compound 3; then compound 1; then compound 2; then compound 4.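

In this assay, tert-butyl in place of neopentyl gives a 41-fold higher number from compound 3 to compound 4 (1.61 log units; beyond the scatter), the largest step yet seen at this aromatic carbon. Tert-butyl also falls behind both other groups, with a 3.3-fold higher number from compound 2 to compound 4 (0.52 log units; beyond the scatter) and a 12-fold higher number from compound 1 to compound 4 (1.06 log units; beyond the scatter), so compound 4 now has the highest number, above even the phenethyl compound. The earlier compounds shown here did not show that exchanging neopentyl for a group only one heavy atom smaller could outweigh every other change at this position. Nothing given here accounts for the size of this step. The compounds shown leave open where isopropyl, a straight butyl chain or an amine on the chain would fall at this carbon.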